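Chloro for hydrogen on the thiophene of compound 2

The source may hold more compounds than are shown below. What is called first, only, known or untested is meant among the compounds shown, and "the series" means these compounds.

Two sulfonamides share the core; compound 1 `COc1cc(NS(=O)(=O)c2ccc(C)cc2[N+](=O)[O-])c2ncccc2c1` and compound 2 `O=S(=O)(Nc1cccc2cccnc12)c1cccs1` are measured. In an assay on isolated protein (HUVEC cells) for inhibition of transcription factor p65 (Homo sapiens) (on this read-out lower numbers stand for stronger inhibition and higher numbers for weaker inhibition), compound 1 gives 2100 nM. In this assay compound 2 gives 3600 nM, the higher of the two numbers, though the gap to compound 1 lies within the scatter. Compound 3 `O=S(=O)(Nc1cccc2cccnc12)c1ccc(Cl)s1` is not yet measured; it carries chloro in place of hydrogen on an aromatic carbon. No measured pair covers this change, so only a small step is expected, in either direction or none beyond the scatter, shown as a 1.4-fold lower number from compound 2 to compound 3 (0.16 log units; within the scatter). Compound 3 is estimated at 2500 nM in this assay, within 900 nM to 7000 nM.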

Compound 3, half-maximal inhibitory concentration: 1300 nM
Compound 3: middle estimate off by 1.9-fold (0.28 log units), on the high side, within the range that was stated.
By their numbers in this assay, from the lowest: compounds 3, 1 and 2 (each within the scatter of the next, the first and the last beyond it).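

In this assay, among these compounds, the change from thiophen-2-yl to 5-chlorothiophen-2-yl gives a 2.8-fold lower number from compound 2 to compound 3 (0.44 log units; beyond the scatter) and is the first single-place step. The aromatic carbon next to the ring sulfur therefore responds to substitution, and chloro is tolerated there without loss. No data at hand give a reason for this step.

Chloro is the only group shown at this carbon, so the trend across substituents remains open. A methyl, a methoxy or an amine at the same position would test whether the step is specific to chloro.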